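The source may hold more compounds than are shown below. What is called first, only, known or untested is meant among the compounds shown, and "the series" means these compounds.

Compound 1 `N#CC1CC(=O)N(c2cnn3c2CN(C(=O)Nc2cc(F)c(F)c(F)c2)C(C2CC2)C3)C1` has no exact figure to start from. In a toxicity assay on HepG2 2.2.15 cells (Homo sapiens) for cytotoxicity, read by CellTiter-Glo (on this read-out lower numbers stand for higher toxicity in this test and higher numbers for lower toxicity in this test), compound 1 gives > 200000 nM, and this is a limit of the assay, not a number. Among the compounds with values here, compound 2 `O=C(Nc1cc(F)c(F)c(F)c1)N1CCCn2ncc(N3CC(c4ccccc4)CC3=O)c2C1`, the only other compound tested, gives > 2000 nM, which is also a limit. The two results therefore offer no measured step to reason from.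

Compound 3 `O=C1CC(c2cnco2)CN1c1cnn2c1CN(C(=O)Nc1cc(F)c(F)c(F)c1)C(C1CC1)C2` keeps the core of compound 1 and changes a single group, with 1,3-oxazol-5-yl in place of cyano on a saturated ring carbon. Within the data shown here, no tested pair shows what this swap does. The expectation is therefore only a modest shift towards lower numbers in this assay, an estimated step of an at least 2.0-fold lower number from compound 1 to compound 3 (0.30 log units; that floor lies within the scatter). For compound 3 the estimated value is 100000 nM, with an expected range from 20000 nM to 300000 nM.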

Compound 3, half-maximal cytotoxic concentration: 139000 nM
For compound 3 the middle estimate is 1.4-fold (0.14 log units) below the measured one; low and high end bracket the measured number.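

In this assay compound 3 gives 139000 nM, the only exact figure among the compounds shown, so the core of compound 1 carrying 1,3-oxazol-5-yl at this saturated ring carbon returns a number that can be read. Putting that group in place of cyano amounts to an at least 1.4-fold lower number from compound 1 to compound 3 (0.15 log units; that floor lies within the scatter); only this floor is known, and it does not show a shift beyond the usual scatter. The full size of the step stays unknown because compound 1 stands at a limit, not a number: the limit of > 200000 nM in this assay, at which 1 of the 3 values shown sits.

As far as these compounds go, whether an amine, a carboxylic acid or a longer chain at this ring carbon would give a lower or higher number remains open. Compound 2 differs from compound 3 in more than one place, so it cannot settle what this position does.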